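This account rests on a few compounds, and the source may have more. Where it says the series, first, only, none or still open, it means among the compounds named here.

Values in a functional assay on the whole organism for inhibition, with Mythimna separata as the target, with a stated time of 5 days; on this read-out higher numbers stand for an effect only at larger amounts of compound and lower numbers for an effect already at smaller amounts:
Compound 1 `CC(C)(C)n1ncc(OCc2nnc(-c3ccccc3Cl)o2)c(Cl)c1=O`: 61200 nM
Compound 2 `CCCCn1ncc(OCc2nnc(-c3ccc(F)cc3)o2)c(Cl)c1=O`: 161000 nM
Compound 3 `CC(C)(C)n1ncc(OCc2nnc(-c3cc(F)c(Cl)c([N+](=O)[O-])c3Cl)o2)c(Cl)c1=O`: > 299000 nM, a limit of the assay

Compound 1 holds the lower of the two true numbers, and compound 2 lies higher, beyond the usual scatter. Compound 3 gives only a limit, > 299000 nM.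

Compound 4 `CC(C)(C)n1ncc(OCc2nnc(-c3ccc(Cl)cc3)o2)c(Cl)c1=O` has the same atoms as compound 1, joined differently, with 4-chlorophenyl in place of 2-chlorophenyl on an aromatic carbon. Among the compounds with values here, no measured pair shows this change alone, so the expectation in this assay is uncertain: a modest step toward a higher number. The estimated step is a 1.5-fold higher number from compound 1 to compound 4 (0.17 log units; within the scatter). For compound 4 the expected value is 90000 nM, with an estimated range of 30000 nM to 250000 nM.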

Compound 4, half-maximal effective concentration: 1900 nM
The estimate for compound 4 lay 47-fold (1.68 log units) above the measured number; the whole stated range lies above it.
By their numbers in this assay, from the lowest: compound 4; then compound 1; then compound 2. At a limit, above all of these: compound 3.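

In this assay, the change from 2-chlorophenyl to 4-chlorophenyl gives a 32-fold lower number from compound 1 to compound 4 (1.51 log units; beyond the scatter). This is the only pair shown that differs in one place, and it shows that, with the same atoms, where the chlorine sits on the phenyl ring matters greatly at this aromatic carbon. No measurement shown accounts for the step. As far as these compounds go, it remains open whether a 4-methoxyphenyl or 4-trifluoromethylphenyl group at this place would keep the lower number. Whether other groups can replace the chlorine at all also remains unsettled.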